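From Cyclohexyl to Benzyl on the Shared Core

The compounds below may be only part of what the source reports. "The series", "measured", "known", "first", "only" and "open" are said of these compounds alone.

Of the compounds shown here, three built on one shared core have been tested in a functional assay on U-251 cells (Homo sapiens) for inhibition, read by sulforhodamine B assay, with a stated time of 48 h, tested at 10 uM; a higher number here means more inhibition at the concentration tested (going by the name of the read-out), a lower number less inhibition. Compound 1 `O=Cc1ccc(-c2cn3ccnc3c(-c3ccc4ncn(C5CCCCC5)c4c3)n2)cc1` carries a formyl group and gives 32%, the highest of the three numbers. Compound 2 `Fc1ccc(-c2cn3ccnc3c(-c3ccc4ncn(C5CCCCC5)c4c3)n2)cc1`, with fluoro in place of formyl on an aromatic carbon, gives 7.94%, and compound 3 `Clc1ccc(-c2cn3ccnc3c(-c3ccc4ncn(C5CCCCC5)c4c3)n2)cc1`, with chloro in place of formyl on an aromatic carbon, gives 11.3%. The step of a number 24.1 percentage points lower from compound 1 to compound 2 (beyond the scatter) and the step of a number 20.7 percentage points lower from compound 1 to compound 3 (beyond the scatter) are both beyond the scatter, while the step of a number 3.4 percentage points higher from compound 2 to compound 3 (within the scatter) lies within it. Compound 1 therefore stands clearly above the other two.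

The next compound keeps the formyl group of compound 1 and alters a different part of the molecule. Compound 4 `O=Cc1ccc(-c2cn3ccnc3c(-c3ccc4ncn(Cc5ccccc5)c4c3)n2)cc1` differs from compound 1 in one way: benzyl in place of cyclohexyl on an aromatic nitrogen. None of the three measured steps concerns this part of the structure; each of them swaps the group on the aromatic carbon, and the cyclohexyl group is the same in every measured compound. Going by the values given here, no measured step bears on the change, so these numbers give no ground to expect a shift in this assay beyond the scatter in either direction. The value of compound 4 in this assay is estimated at 30%, within a range from 10% to 55%, which amounts to an expected step of a number 2 percentage points lower from compound 1 to compound 4 (within the scatter).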

Compound 4, a percentage reported as inhibition, at one concentration (the size of the read-out at that concentration, not a potency): 32%
Compound 4: the middle estimate sits 2 percentage points below what was measured; low and high end bracket the measured number.
By their numbers in this assay, from the lowest: compounds 2 and 3 (each within the scatter of the next); then compounds 1 and 4 (each within the scatter of the next).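

Going by these compounds alone, until this result, every measured compound carried cyclohexyl on the aromatic nitrogen, so nothing showed how this assay responds to a change at that position. With benzyl in place of cyclohexyl, the read-out shows no change at the digits printed from compound 1 to compound 4 (within the scatter): on a compound carrying the formyl group, a six-membered non-aromatic ring of carbon and the benzyl group with its six-membered aromatic ring give the same number, whereas swapping formyl for fluoro or chloro on the aromatic carbon had moved the number beyond the scatter. No measurement here offers an explanation for why this exchange leaves the number unchanged.

Benzyl appears only alongside the formyl group, so it remains open whether the same exchange would leave the number unchanged in compounds carrying fluoro or chloro on the aromatic carbon. Also open, as far as these compounds go, is how the number would respond to a quite different group on the aromatic nitrogen, such as a short chain like methyl, or a benzyl group whose ring carries an amine or a carboxylic acid.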